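The source may report more compounds than this note shows. Statements on the series, on what has been measured and on what is new or still open speak of the compounds shown alone.

Compound 2, `Nc1scc(CN2CCN(c3cc(F)ccc3F)CC2)c1C(=O)c1ccc(Cl)cc1`, was tested in a functional assay on CHO cells with adenosine receptor A1 (Homo sapiens) as the target, read by cAMP accumulation and immunoassay, with a stated time of 6 min, tested at 1 uM (on this read-out higher numbers stand for a weaker effect at the one concentration tested and lower numbers for a stronger effect), and gave -59%. Among the two numbers in hand it stands lowest, and its nearest neighbour is compound 1, `Nc1scc(CN2CCN(C3CCCCCC3)CC2)c1C(=O)c1ccc(Cl)cc1`, which in this assay gives 3.7%. Going by the values given here, the one measured step between these two, a number 62.7 percentage points lower from compound 1 to compound 2 (beyond the scatter), came from the change of cycloheptyl to 2,5-difluorophenyl on an amine nitrogen in a ring.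

Compound 3, `Nc1scc(CN2CCN(c3c(F)cc(F)cc3F)CC2)c1C(=O)c1ccc(Cl)cc1`, has not been measured in this assay. It differs from compound 2 in one place: 2,4,6-trifluorophenyl in place of 2,5-difluorophenyl on an amine nitrogen in a ring

Among the compounds with values here, no measured step bears directly on this change; the only step in hand, from compound 1 to compound 2, swapped a non-aromatic ring for an aromatic one, whereas here one fluorinated aromatic ring is replaced by another. Compound 3 is therefore expected to stay close to compound 2 in this assay, with a step of about a number 9 percentage points higher from compound 2 to compound 3 (within the scatter), not beyond the usual scatter. The estimate for compound 3 is -50%, within a range from -85% to -10%.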

Compound 3, a percentage reported as activity, at one concentration (the size of the read-out at that concentration, not a potency): -56%
Beside the measured number, compound 3's estimate is 6 percentage points above it, within the range that was stated.
By their numbers in this assay, from the lowest: compounds 2 and 3 (each within the scatter of the next); then compound 1.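

On the amine nitrogen in a ring, exchanging 2,5-difluorophenyl for 2,4,6-trifluorophenyl left the read-out in this assay without a change beyond the scatter, with a number 3 percentage points higher from compound 2 to compound 3 (within the scatter), so this position accepts both fluorine patterns shown. The large gap to the cycloheptyl compound therefore no longer rests on one aromatic group alone: a number 59.7 percentage points lower from compound 1 to compound 3 (beyond the scatter) is of the same order as a number 62.7 percentage points lower from compound 1 to compound 2 (beyond the scatter), and both fluorinated phenyl groups part from cycloheptyl in the same direction. Nothing in hand explains why the two fluorinated groups read alike, or why both differ from cycloheptyl.

It remains open whether the large gap needs fluorine at all, since the compounds shown do not say how an unsubstituted phenyl, a chlorophenyl, a methoxyphenyl or a pyridine ring would read at this nitrogen. They also leave open whether a smaller saturated ring such as cyclohexyl, or an open chain such as butyl, would read like cycloheptyl, and whether the stronger effect seen at this one concentration would hold at other concentrations.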